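A bromine-bearing ring in place of two chlorines

The source may report more compounds than this note shows. Statements on the series, on what has been measured and on what is new or still open speak of the compounds shown alone.

Compound 2 `NC1=NC2(CCOCC2)N(OCCCOc2ccc(Cl)c(Cl)c2)C(N)=N1` stands at the top of what the assay can report: in an assay on isolated protein for inhibition of Dihydrofolate reductase (Homo sapiens), read by spectrophotometry, using NADPH, with stated times of 5 s and 6 min, tested at 5 uM (on this read-out higher numbers stand for a stronger effect at the one concentration tested and lower numbers for a weaker effect), compound 2 gives > 90%, which is a limit and not a number. Compound 1 `NC1=NC2(CCOCC2)N(OCCCOc2ccc(F)cc2)C(N)=N1` likewise reaches a limit: in this assay compound 1 gives > 90%. The step that the two limits leave unreadable from compound 1 to compound 2 therefore stays unreadable, as the limit of > 90% in this assay, at which 2 of the 2 values shown sit, shows. Compound 3 `NC1=NC2(CCOCC2)N(OCCCOc2cccc(Br)c2)C(N)=N1` differs from compound 2 by 3-bromophenyl in place of 3,4-dichlorophenyl on an oxygen on a saturated carbon. Going by the values given here, no measured step reads on such a change, so the estimated step of a number no higher from compound 2 to compound 3 (the limit leaves the size open) is expected to stay within the scatter. Compound 3 is expected to give 90% in this assay, between 75% and 96%.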

Compound 3, a percentage reported as inhibition, at one concentration (the size of the read-out at that concentration, not a potency): 86.7%
For compound 3 the middle estimate is 3.3 percentage points above the measured one; measured number inside the range.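

Going by these compounds alone, compound 3 gives the first true number at this position in this assay, where the other two compounds sit at a limit, so a change of the ring on the oxygen can now be read, if only in part. On these data alone, the change reads as a number at least 3.3 percentage points lower from compound 2 to compound 3 (that floor lies within the scatter) and as a number at least 3.3 percentage points lower from compound 1 to compound 3 (that floor lies within the scatter); both are floors, so the real size stays open, and the step between the two limits cannot be read.

As far as these compounds go, whether an amine or a carboxylic acid in place of the ring would keep this effect stays open. So does the effect of a longer chain.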